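A few compounds are considered here, and "the series" means these few. Any claim that something is new, unique, unknown or untested is made for them only; others in the source may bear on it.

Working notes on a small pyrazoline series tested in a functional assay on HCC1806 cells (Homo sapiens) for inhibition, read by sulforhodamine B assay, tested at 10 uM; a lower number here means less inhibition, a higher number more inhibition at the concentration tested (going by the name of the read-out).

Compound 1 `CN1CCN(c2ccc(C3=NN(C(=O)CCCl)C(c4ccc(N(C)C)cc4)C3)cc2)CC1` carries a 4-methylpiperazin-1-yl group on the aryl ring and a (2-chloroethyl)carbonyl on the ring nitrogen; in this assay compound 1 gives 1.7%. Compound 2 `COC(=O)CC(=O)N1N=C(c2ccc(N3CCN(C)CC3)cc2)CC1c1ccc(N(C)C)cc1` differs from compound 1 by methoxycarbonyl in place of chloromethyl on a saturated chain carbon bound to a carbonyl carbon; in this assay compound 2 gives -8.3%. The step of a number 10 percentage points lower from compound 1 to compound 2 (within the scatter) does not separate the two compounds. Compound 3 `CN(C)c1ccc(C2CC(c3ccc(-n4cncn4)cc3)=NN2C(=O)CCCl)cc1` differs from compound 1 by 1H-1,2,4-triazol-1-yl in place of 4-methylpiperazin-1-yl on an aromatic carbon; in this assay compound 3 gives -3.4%, and the step of a number 5.1 percentage points lower from compound 1 to compound 3 (within the scatter) likewise leaves both compounds within the same band. Compound 2 and compound 3 sit close together as well, so nothing here is told apart in this assay.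

Compound 4 `COC(=O)CC(=O)N1N=C(c2ccc(-n3cncn3)cc2)CC1c1ccc(N(C)C)cc1` is not yet measured. It differs from compound 3 by methoxycarbonyl in place of chloromethyl on a saturated chain carbon bound to a carbonyl carbon. This is the same change as that from compound 1 to compound 2, made on a different core: the two cores differ by 1H-1,2,4-triazol-1-yl in place of 4-methylpiperazin-1-yl on an aromatic carbon. The earlier step of this change, a number 10 percentage points lower from compound 1 to compound 2 (within the scatter), stayed within the scatter, so the step from compound 3 to compound 4 is expected to be of similar size, a number 4.6 percentage points lower from compound 3 to compound 4 (within the scatter), resting on that single precedent. Compound 4 is therefore estimated to give -8% in this assay, expected to lie between -25% and 10%, which means essentially no inhibition at the tested concentration.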

Compound 4, a percentage reported as inhibition, at one concentration (the size of the read-out at that concentration, not a potency): -7.8%
Compound 4: the middle estimate sits 0.2 percentage points below what was measured; the range from low to high includes it.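

Methoxycarbonyl in place of chloromethyl can't be told apart between the two cores, with a number 4.4 percentage points lower from compound 3 to compound 4 (within the scatter) in this assay as the new step: the same change on two cores in this assay, a number 10 percentage points lower (within the scatter) from compound 1 to compound 2 and a number 4.4 percentage points lower (within the scatter) from compound 3 to compound 4, 5.6 percentage points apart, within the scatter of two such steps

The other change in the square, 1H-1,2,4-triazol-1-yl in place of 4-methylpiperazin-1-yl, behaves the same way, with a number 0.5 percentage points higher from compound 2 to compound 4 (within the scatter) as the new step: the same change on two cores in this assay, a number 5.1 percentage points lower (within the scatter) from compound 1 to compound 3 and a number 0.5 percentage points higher (within the scatter) from compound 2 to compound 4, 5.6 percentage points apart, within the scatter of two such steps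

Among these compounds, this shows only that each change stays within the scatter on both cores, so the agreement is one between steps that cannot themselves be separated from zero; it does not show that either change would carry over in the same way on a core with measurable inhibition, and it gives no test of whether the steps add up.

All four compounds lie in one band, so the series gives no handle yet on what would raise inhibition in this assay at the tested concentration. Open, going by these compounds, are, for instance, a carboxylic acid in place of methoxycarbonyl, a longer chain in place of 2-chloroethyl, and a primary amine in place of 4-methylpiperazin-1-yl on the aromatic carbon.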